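Series notes: the step from compound 3 to compound 4

The source may report more compounds than this note shows. Statements on the series, on what has been measured and on what is new or still open speak of the compounds shown alone.

Compound 1 `Nc1nc(Cl)c2nnn([C@H]3CCCC[C@H]3CO)c2n1` stands apart from the rest in both core and side chain; in an ADME assay on L1210/0 cells (Mus musculus) for cytotoxicity, with a stated time of 48 h (a higher number here means a weaker inhibitor, a lower number a stronger inhibitor), compound 1 gives 95500 nM. Compound 2 `Oc1ncnc2c1ncn2C[C@@H]1C[C@H](O)c2ccccc21` and compound 3 `COc1ncnc2c1ncn2C[C@@H]1C[C@H](O)c2ccccc21` share a core and a side chain and differ only in the group on the ring oxygen. For compound 2 the assay reports only a limit, > 200000 nM. For compound 3 the assay likewise reports only a limit, > 200000 nM. The step that the two limits leave unreadable from compound 2 to compound 3 therefore cannot be read. On the numbers shown compound 3 stands at the weak end without a numerical value of its own, being one of the two that sit at the limit of > 200000 nM in this assay, at which 2 of the 3 values shown sit.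

Compound 4 `COc1ccccc1-c1ncnc2c1ncn2C[C@@H]1C[C@H](O)c2ccccc21` differs from compound 3 by 2-methoxyphenyl in place of methoxy on an aromatic carbon. For the measured compounds named here, no measured step touches this position, and the one step between neighbours is unreadable, so no direction can be drawn from the series; a considerably larger group enters where the series so far shows only weak inhibition. Compound 4 is therefore expected to remain weak, with a step of an at least 1.3-fold lower number from compound 3 to compound 4 (0.12 log units; that floor lies within the scatter). The estimate for compound 4 is 150000 nM, in the range 40000 nM to 400000 nM, with a fair chance that the assay again reports only a limit.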

Compound 4, half-maximal inhibitory concentration: > 200000 nM
Compound 4: only a limit was reported; the forecaster's own chance of this, stated with the estimate: 60%; middle value at least 1.3-fold (0.12 log units) away from the limit.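

In this assay compound 4 gives only a limit, > 200000 nM. Its steps from compound 2 and compound 3 therefore cannot be read: the limit of > 200000 nM in this assay, at which 3 of the 4 values shown sit.

The compounds shown leave open whether any group on this aromatic carbon of the shared core gives a numerical value in this assay.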